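The source may report more compounds than this note shows. Statements on the series, on what has been measured and on what is new or still open speak of the compounds shown alone.

Measured so far in a functional assay on HT-29 cells (Homo sapiens) for inhibition, read by MTT assay, with a stated time of 48 h; on this read-out higher numbers stand for weaker inhibition and lower numbers for stronger inhibition:
- compound 1, `COc1cc(/C=C/c2ccc(NC(=O)/C=C/c3ccc(OC)c(OC)c3)cc2)cc(OC)c1`: 960 nM
- compound 2, `COc1cc(/C=C/c2ccc(NC(=O)/C=C/c3ccc(F)cc3)cc2)cc(OC)c1`: 11600 nM

Among the compounds with values here, compound 2 holds the higher of the two numbers, which on this read-out means the weaker inhibition; its only neighbour is compound 1, and the step of a 12-fold higher number from compound 1 to compound 2 (1.08 log units; beyond the scatter) separates them. Compound 3, `COc1cc(/C=C/c2ccc(NC(=O)/C=C/c3ccc(F)cc3F)cc2)cc(OC)c1`, is not yet measured. It keeps the whole shared core of compound 2 and differs from it in one place: fluoro in place of hydrogen on an aromatic carbon. Within the data shown here, only one measured step exists, and it concerns a different change, the exchange of the entire substitution pattern on the same ring rather than the entry of a single fluoro, so it offers little direct guidance. Among the measured compounds shown here, with no closer precedent, the number for compound 3 in this assay is expected to stay near that of compound 2, a step of a 1.2-fold lower number from compound 2 to compound 3 (0.06 log units; within the scatter) that is not expected to exceed the usual scatter. Compound 3 is therefore estimated at 10000 nM, with a range from 3500 nM to 28000 nM.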

Compound 3, half-maximal inhibitory concentration: 18100 nM
Estimate against measurement, compound 3: 1.8-fold (0.26 log units) below; the measured number falls inside the stated range.
By their numbers in this assay, from the lowest: compound 1; then compounds 2 and 3 (each within the scatter of the next).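

In this assay, fluoro in place of hydrogen on this aromatic carbon, ortho to a large group and meta to a fluoro group, gives a 1.6-fold higher number from compound 2 to compound 3 (0.19 log units; within the scatter), so the 4-fluorophenyl and 2,4-difluorophenyl compounds cannot be told apart here. The 2,4-difluorophenyl group also stays far from the 3,4-dimethoxyphenyl group, with a 19-fold higher number from compound 1 to compound 3 (1.28 log units; beyond the scatter), so this second fluoro does not close the large gap to compound 1. Nothing at hand gives a reason for either result.

From the compounds shown here alone, it remains open whether an amino or hydroxyl group on this same aromatic carbon would also stay within the scatter of compound 2. Also open, going by these compounds, is whether one methoxy group alone, on either of the two positions it holds in compound 1, would give a number like that of compound 1 or like those of the fluoro compounds.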